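A methoxy on the isopropoxy chain of compound 3

The compounds below may be only part of what the source reports. "The series", "measured", "known", "first", "only" and "open" are said of these compounds alone.

In an ADME assay on microsomes from liver (Rattus norvegicus) for metabolic stability (on this read-out lower numbers stand for slow clearance and higher numbers for fast clearance), compound 1 `CCc1cnc(-c2cc(Oc3ccc(S(C)(=O)=O)cc3)cc(OC(C)C)c2)[nH]c1=O` gives 171 mL/min/kg. Compound 2 `CC(C)Oc1cc(Oc2ccc(S(C)(=O)=O)cc2)cc(-c2ncc(Cl)c(=O)[nH]2)c1` gives < 25.4 mL/min/kg, which is a limit of the assay and not a number. Compound 3 `CC(C)Oc1cc(Oc2cnc(C(=O)N(C)C)cn2)cc(-c2nccc(=O)[nH]2)c1` gives 47 mL/min/kg, the lower of the two actual numbers, and the gap up to compound 1 lies beyond the scatter.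

Compound 4 `COC[C@H](C)Oc1cc(Oc2cnc(C(=O)N(C)C)cn2)cc(-c2nccc(=O)[nH]2)c1` departs from compound 3 in a single place: methoxy in place of hydrogen on a saturated chain carbon, two bonds along the chain from an oxygen on an aromatic ring. The methoxy stands in place of hydrogen on a saturated chain carbon, two bonds along the chain from an oxygen on an aromatic ring, so that isopropoxy becomes 1-(methoxymethyl)ethoxy.

Among the compounds with values here, only one measured step is available for comparison. That step, an at least 6.7-fold lower number from compound 1 to compound 2 (0.82 log units; beyond the scatter), puts chloro in place of ethyl on an aromatic carbon and lies beyond the scatter. It was measured at a different place in the structure and involves a different kind of change, so it offers no size to carry over. Within the data shown here, no measured step touches the isopropoxy chain.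

No shift beyond the scatter is therefore expected in this assay, and the estimated step is a 1.1-fold higher number from compound 3 to compound 4 (0.03 log units; within the scatter). Starting from compound 3 at 47 mL/min/kg, the estimate for compound 4 is 50 mL/min/kg, expected to fall between 25 mL/min/kg and 110 mL/min/kg.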

Compound 4, clearance in the Rattus norvegicus assay: < 25.4 mL/min/kg
Compound 4: no number, only a limit (the forecaster's own chance of this, stated with the estimate: 15%); at least 1.9-fold (0.29 log units) between middle value and limit.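

Within the data shown here, the earlier compounds all carry an unchanged isopropoxy chain, so this is the first reading of a change at this position. In the Rattus norvegicus assay compound 4 gives < 25.4 mL/min/kg, which is a limit of the assay and not a number. In the Rattus norvegicus assay the step is an at least 1.8-fold lower number from compound 3 to compound 4 (0.26 log units; that floor lies within the scatter), which shows that methoxy on the saturated chain carbon does not carry the number upward, although the floor of the step does not by itself establish a shift beyond the scatter. That limit is why the true size of the step cannot be given: the limit of < 25.4 mL/min/kg in the Rattus norvegicus assay, at which 2 of the 4 values shown sit. In a physicochemical assay for solubility, in phosphate buffer, measured as kinetic solubility, with a stated time of 24 h, at pH 6.5 (a lower number here means a less soluble compound, a higher number a more soluble compound), compound 3 gives 373000 nM and compound 4 gives 728000 nM. In the physicochemical assay the same change gives a 2.0-fold higher number from compound 3 to compound 4 (0.29 log units; within the scatter), so no shift beyond the scatter is seen there.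

The compounds shown leave open whether a hydroxy, an amine or a longer chain in place of the methoxy would read the same way in the Rattus norvegicus assay. They also leave open whether 1-(methoxymethyl)ethoxy would give a step of similar direction in the Rattus norvegicus assay on the core of compound 1, which gives 171 mL/min/kg.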